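A few compounds are considered here, and "the series" means these few. Any claim that something is new, unique, unknown or untested is made for them only; others in the source may bear on it.

Series notes. In a functional assay on CHO cells for agonist activity at 5-hydroxytryptamine receptor 4 (Homo sapiens), read by a luciferase reporter and cAMP accumulation, with a stated time of 4 h (on this read-out lower numbers stand for smaller maximal responses and higher numbers for larger maximal responses), compound 1 `CC(C)c1nc(C(=O)NCC2CCN(C3CCOCC3)CC2)c2ccccn12` gives 29%, compound 2 `CC(C)c1nc(-c2nnc(C3CCN(CC4CCC4)CC3)o2)c2ccccn12` gives 63%, and compound 3 `CC(C)c1nc(C(=O)NC[C@@H]2[C@H]3CN(CC4CCC4)C[C@@H]23)c2ccccn12` gives 50%. Compound 3 thus stands second highest of the three numbers: compound 2 lies nearest, its number higher by a margin beyond the scatter, and compound 1 lies furthest, its number lower, also beyond the scatter. Compound 4 `COC(=O)N1CCC(N2C[C@@H]3[C@@H](CNC(=O)c4nc(C(C)C)n5ccccc45)[C@@H]3C2)CC1` is not yet measured. It differs from compound 3 in one place: 1-(methoxycarbonyl)piperidin-4-yl in place of cyclobutylmethyl on an amine nitrogen in a ring. Going by the values given here, no step between two measured compounds matches this change, so the direction rests on little. A modest decrease in maximal response, somewhat beyond the scatter, is expected: a number 10 percentage points lower from compound 3 to compound 4 (within the scatter). Compound 4 is accordingly estimated at 40%, with a range from 20% to 65%.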

Compound 4, largest response reached (Emax), in percent of the reference or control that the assay uses: 42%
For compound 4 the middle estimate is 2 percentage points below the measured one, and the stated range covers the measured number.
By their numbers in this assay, from the lowest: compound 1; then compounds 4 and 3 (each within the scatter of the next); then compound 2.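

In this assay, going by these compounds alone, 1-(methoxycarbonyl)piperidin-4-yl in place of cyclobutylmethyl on an amine nitrogen in a ring gives a number 8 percentage points lower from compound 3 to compound 4 (within the scatter) and is the first one-place step. At this position, a substituent with a six-membered ring and two hydrogen-bond acceptors therefore gives a maximal response that cannot be told apart from that of the small carbocyclic group. No measurement shown bears on the reason for this result. On these data alone, it remains open how a free piperidin-4-yl amine or a carboxylic acid in place of the methoxycarbonyl would read here. As far as these compounds go, a longer alkyl chain on this nitrogen is equally open.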